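Carbamate replacing the sulfonamide on the saturated ring

This account rests on a few compounds, and the source may have more. Where it says the series, first, only, none or still open, it means among the compounds named here.

Compound 1 `Cc1cccc(C(=O)Nc2ccc3c(c2)CC(NS(C)(=O)=O)C3)c1-c1ccc(Cl)cc1` gives 6.6 nM in an assay for inhibition of apolipoprotein B-100 (Homo sapiens), tested at 100 nM; on this read-out higher numbers stand for weaker inhibition and lower numbers for stronger inhibition. Compound 2 `Cc1cccc(C(=O)Nc2ccc3c(c2)CC(NS(=O)(=O)c2cccs2)C3)c1-c1ccc(F)cc1` gives 1.4 nM in this assay, and compound 3 `Cc1cccc(C(=O)Nc2ccc3c(c2)CC(NS(=O)(=O)c2cccs2)C3)c1-c1ccc(Cl)cc1` gives 3 nM. Compound 3 therefore stands second highest of the three numbers: compound 2 lies nearest and lower, compound 1 furthest and higher. The halogen exchange on the aromatic carbon is a modest step, a 2.1-fold higher number from compound 2 to compound 3 (0.33 log units; beyond the scatter).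

Compound 4 `COC(=O)NCC1Cc2ccc(NC(=O)c3cccc(C)c3-c3ccc(Cl)cc3)cc2C1` differs from compound 3 in one place: ((methoxycarbonyl)amino)methyl in place of ((thiophen-2-yl)sulfonyl)amino on a saturated ring carbon. Going by the values given here, only one measured step touches the same position, a 2.2-fold lower number from compound 1 to compound 3 (0.34 log units; beyond the scatter), and it is modest; it exchanges the group on the sulfonyl sulfur while keeping the sulfonylamino link itself. Among the compounds with values here, compound 4 removes that link altogether and inserts a methylene before a carbamate nitrogen, a change no measured pair covers. Since the two groups tried at this position gave numbers only a modest span apart, the series appears tolerant there, and a moderate rise rather than a collapse is expected. Compound 4 is estimated at 8 nM, with a range from 2.5 nM to 25 nM. The expected step is thus a 2.7-fold higher number from compound 3 to compound 4 (0.43 log units; beyond the scatter), with wide uncertainty.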

Compound 4, half-maximal inhibitory concentration: 8.7 nM
Beside the measured number, compound 4's estimate is 1.1-fold (0.04 log units) below it, and the stated range covers the measured number.
By their numbers in this assay, from the lowest: compound 2; then compound 3; then compounds 1 and 4 (each within the scatter of the next).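

Notes on the saturated ring carbon: in this assay, the sulfonylamino link can be lost without a collapse, as ((methoxycarbonyl)amino)methyl in place of ((thiophen-2-yl)sulfonyl)amino gives a 2.9-fold higher number from compound 3 to compound 4 (0.46 log units; beyond the scatter). Against the smaller sulfonamide, the same carbamate gives a 1.3-fold higher number from compound 1 to compound 4 (0.12 log units; within the scatter), so ((methoxycarbonyl)amino)methyl and methanesulfonamido cannot be told apart here, and among the three chloro compounds only the thiophene sulfonamide of compound 3 stands beyond the scatter of both other groups. No data are available to explain these differences.

The change to compound 4 alters the link and the group's attachment together, inserting a methylene and replacing the sulfonyl with a carbonyl, so the compounds shown do not separate the contribution of either part. Also open, as far as these compounds go, are how a carbamate attached directly to the ring carbon, a primary amine or a carboxylic acid at this position would read, and whether the carbamate step would hold with fluoro in place of chloro on the aromatic carbon.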